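Working notes: from compound 2 to compound 3

The source may hold more compounds than are shown below. What is called first, only, known or untested is meant among the compounds shown, and "the series" means these compounds.

Measured so far:
compound 1 `CC(=O)NC(=S)Nc1ccc(Br)c2ccccc12`: 2420 nM
compound 2 `O=C(NC(=S)Nc1ccc(Br)c(C(F)(F)F)c1)c1ccccc1`: 1170 nM

In an assay for inhibition of epoxide hydrolase 1 (Homo sapiens), read by fluorescence, using microsomes (on this read-out higher numbers stand for weaker inhibition and lower numbers for stronger inhibition), compound 2 gives 1170 nM, the lowest of the two numbers; compound 1 gives 2420 nM, a number beyond the scatter above it. Compound 3 `O=C(NC(=S)Nc1ccc(Br)cc1)c1ccccc1` differs from compound 2 by hydrogen in place of trifluoromethyl on an aromatic carbon. Among the compounds with values here, no measured pair shows this change, so there is nothing to size it from; a modest weakening, close to the scatter, is expected. Compound 3 is estimated at 2500 nM (range 800 nM to 8000 nM). The expected step is a 2.1-fold higher number from compound 2 to compound 3 (0.33 log units; beyond the scatter).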

Compound 3, half-maximal inhibitory concentration: 3440 nM
Compound 3: the middle estimate sits 1.4-fold (0.14 log units) below what was measured; the range from low to high includes it.
By their numbers in this assay, from the lowest: compound 2; then compounds 1 and 3 (each within the scatter of the next).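

Within the data shown here, this is the first sized change at this position: in this assay, hydrogen in place of trifluoromethyl on an aromatic carbon, ortho to a bromo group, gives a 2.9-fold higher number from compound 2 to compound 3 (0.47 log units; beyond the scatter). Trifluoromethyl at this carbon therefore gives a modest but real advantage over hydrogen in this pair. Nothing available accounts for the step.

Among the compounds shown, this carbon carries only hydrogen or trifluoromethyl, so the outcome with a chloro, methyl or methoxy group remains open. Going by these compounds, whether the same step holds on the core of compound 1 also remains open.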